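From Dichlorophenyl to Dimethoxyphenyl: An Antiproliferative Estimate

The compounds below may be only part of what the source reports. "The series", "measured", "known", "first", "only" and "open" are said of these compounds alone.

Of the compounds shown here, three sharing one core have been measured in a functional assay on CCRF-CEM cells (Homo sapiens) for antiproliferative activity, with a stated time of 72 h; a lower number here means a stronger inhibitor, a higher number a weaker inhibitor. Compound 1 (`OC[C@H]1O[C@@H](n2cnc3c(NCc4cccc(F)c4)ncnc32)[C@H](O)[C@@H]1O`) gives 4000 nM, compound 2 (`OC[C@H]1O[C@@H](n2cnc3c(NCc4ccc(Cl)cc4)ncnc32)[C@H](O)[C@@H]1O`) gives 10200 nM, and compound 3 (`OC[C@H]1O[C@@H](n2cnc3c(NCc4ccc(Cl)c(Cl)c4)ncnc32)[C@H](O)[C@@H]1O`) gives 3800 nM. Compound 3 therefore stands at the low end of this small set, level with compound 1 and apart from compound 2. Changing the phenyl group has so far produced only small steps: a 2.6-fold higher number from compound 1 to compound 2 (0.41 log units; beyond the scatter), a 1.1-fold lower number from compound 1 to compound 3 (0.02 log units; within the scatter) and a 2.7-fold lower number from compound 2 to compound 3 (0.43 log units; beyond the scatter).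

Compound 4 (`COc1cccc(CNc2ncnc3c2ncn3[C@@H]2O[C@H](CO)[C@@H](O)[C@H]2O)c1OC`) differs from compound 3 in one place: 2,3-dimethoxyphenyl in place of 3,4-dichlorophenyl on a saturated chain carbon bound to a nitrogen on an aromatic ring. Going by the values given here, no measured step brings in a dimethoxyphenyl group, so these steps offer only a rough guide to size. A modest step is expected, and a higher number seems more likely because compound 3 gives 3800 nM at the low end of the set. In this assay, the estimated change is a 1.8-fold higher number from compound 3 to compound 4 (0.27 log units; within the scatter). Compound 4 is expected to give about 7000 nM, with an estimated range of 2500 nM to 20000 nM.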

Compound 4, half-maximal inhibitory concentration: > 166000 nM
Compound 4: no number, only a limit (the forecaster's own chance of this, stated with the estimate: 10%); middle value at least 23-fold (1.37 log units) away from the limit.
By their numbers in this assay, from the lowest: compounds 3 and 1 (each within the scatter of the next); then compound 2. At a limit, above all of these: compound 4.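

In this assay compound 4 gives no number, only a limit: the limit of > 166000 nM in this assay, at which 1 of the 4 values shown sits. Going by these compounds alone, replacing the halogen-bearing phenyl groups with 2,3-dimethoxyphenyl therefore produces large steps (an at least 43-fold higher number from compound 3 to compound 4 (1.64 log units; beyond the scatter) and an at least 16-fold higher number from compound 2 to compound 4 (1.21 log units; beyond the scatter) and an at least 41-fold higher number from compound 1 to compound 4 (1.61 log units; beyond the scatter)), each read against that limit and each well beyond the modest steps seen among the earlier compounds. This position on the saturated chain carbon can therefore matter far more than compounds 1, 2 and 3 alone suggested, since changing the group there need not leave the number within a narrow band.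

With only one dimethoxyphenyl group shown, nothing separates the effect of having two methoxy groups from the effect of where they sit on the ring. From the compounds shown here alone, how a phenyl ring with a single methoxy group, a hydroxy group or an amine would behave in this place also remains open.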